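The source may report more compounds than this note shows. Statements on the series, on what has been measured and on what is new or still open speak of the compounds shown alone.

In a functional assay on A549 cells (Homo sapiens) for antiproliferative activity, read by MTT assay, with a stated time of 72 h (on this read-out higher numbers stand for weaker inhibition and lower numbers for stronger inhibition), three compounds have been measured:

- compound 1 `S=C(Sc1ccccc1)N1CCOCC1` gives 2520 nM
- compound 2 `CC(C)(C)c1ccc(SC(=S)N2CCCCC2)cc1` gives 9130 nM
- compound 3 `CC(C)(C)OC(=O)N1CCN(C(=S)Sc2ccc(F)cc2)CC1` gives 1560 nM

Compound 3 cannot be separated from compound 1 within the scatter, while compound 2 lies beyond the scatter from compound 3, on the side of weaker inhibition. The next compound, compound 4 `Cc1cccc(SC(=S)N2CCN(C(=O)OC(C)(C)C)CC2)c1`, carries 3-methylphenyl in place of 4-fluorophenyl on a sulfur and is otherwise the same as compound 3. Within the data shown here, no measured pair isolates this exchange, so no step beyond the scatter is expected. The expected change is small and slightly toward weaker inhibition, estimated as a 1.4-fold higher number from compound 3 to compound 4 (0.15 log units; within the scatter) in this assay and within the uncertainty of the estimate. For compound 4 the estimated value is 2200 nM, with an expected range from 750 nM to 6500 nM in this read-out.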

Compound 4, half-maximal inhibitory concentration: 914 nM
Beside the measured number, compound 4's estimate is 2.4-fold (0.38 log units) above it; measured number inside the range.
By their numbers in this assay, from the lowest: compounds 4, 3 and 1 (each within the scatter of the next, the first and the last beyond it); then compound 2.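

Among these compounds, the first matched pair at this position puts 3-methylphenyl in place of 4-fluorophenyl on a sulfur, with the rest of the molecule unchanged, and in this assay this gives a 1.7-fold lower number from compound 3 to compound 4 (0.23 log units; within the scatter). Compound 3 and compound 4 therefore cannot be separated, so this position accepts either group with no change that can be read beyond the scatter. Nothing available offers an explanation for this result. The compounds shown leave open whether a carboxylic acid or an amine on the phenyl ring would keep a number in this range.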